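This account rests on a few compounds, and the source may have more. Where it says the series, first, only, none or still open, it means among the compounds named here.

Working notes, amide variation on the shared core.

Three compounds of this set have numbers in an in vitro functional assay on CHO/Galpha16 cells for antagonist activity at C-C chemokine receptor type 8 (Homo sapiens), read by FLIPR; a lower number here means a stronger inhibitor, a higher number a weaker inhibitor. Compound 1 `CCCC(=O)N1CCC(NS(=O)(=O)c2ccc(NC(=O)c3cccc(C)c3)c3ccccc23)CC1` gives 5.1 nM, compound 2 `CCCC(=O)N1CCC(NS(=O)(=O)c2ccc(NC(=O)C(CC)CC)c3ccccc23)CC1` gives 639 nM, and compound 3 `CCCCc1ccc(C(=O)Nc2ccc(S(=O)(=O)NC3CCN(C(=O)CCC)CC3)c3ccccc23)cc1` gives 15.3 nM. Compound 3 therefore stands second of the three: a 3.0-fold higher number from compound 1 to compound 3 (0.48 log units; beyond the scatter) separates it from compound 1, while a 42-fold lower number from compound 2 to compound 3 (1.62 log units; beyond the scatter) separates it from compound 2. The group on the amide carbonyl carbon is decisive here; the two aromatic groups of compound 1 and compound 3 lie close together, whereas the branched alkyl group of compound 2 falls far behind, as a 130-fold higher number from compound 1 to compound 2 (2.10 log units; beyond the scatter) shows.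

Compound 4 `CCCC(=O)N1CCC(NS(=O)(=O)c2ccc(NC(=O)c3cc(C)oc3C(F)(F)F)c3ccccc23)CC1` has not been measured. It differs from compound 3 in one place: 5-methyl-2-(trifluoromethyl)furan-3-yl in place of 4-butylphenyl on a carbonyl carbon. The entering group keeps an aromatic ring, with one hetero atom and one hydrogen-bond acceptor counted. Within the data shown here, the steps that bear on this position are the aromatic-to-aromatic exchange a 3.0-fold higher number from compound 1 to compound 3 (0.48 log units; beyond the scatter), which was modest, and the aromatic-to-aliphatic exchange a 42-fold lower number from compound 2 to compound 3 (1.62 log units; beyond the scatter), which was large. Since compound 4 retains an aromatic ring, a modest step is expected in this assay, a 1.2-fold higher number from compound 3 to compound 4 (0.07 log units; within the scatter), direction uncertain. Compound 4 is estimated at 18 nM, expected between 4 nM and 80 nM.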

Compound 4, half-maximal inhibitory concentration: 46.9 nM
The estimate for compound 4 lay 2.6-fold (0.42 log units) below the measured number, within the range that was stated.
By their numbers in this assay, from the lowest: compound 1; then compound 3; then compound 4; then compound 2.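

In this assay, the five-membered aromatic ring of compound 4 stays much closer to the six-membered aromatic groups than to pentan-3-yl: the step from the branched alkyl group is large (a 14-fold lower number from compound 2 to compound 4 (1.13 log units; beyond the scatter)), while the steps from the two phenyl-bearing compounds are modest (a 3.1-fold higher number from compound 3 to compound 4 (0.49 log units; beyond the scatter); a 9.2-fold higher number from compound 1 to compound 4 (0.96 log units; beyond the scatter)). The aromatic group on this carbonyl carbon therefore need not be a ring of carbon only, although 5-methyl-2-(trifluoromethyl)furan-3-yl leaves compound 4 weaker than both compound 1 and compound 3. Nothing available explains this ordering.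

The compounds shown do not separate the furan ring from its methyl and trifluoromethyl groups. On these data alone, it also remains open how an unsubstituted furan-3-yl group or a pyridine ring would read at this position.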